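The source may hold more compounds than are shown below. What is called first, only, known or untested is meant among the compounds shown, and "the series" means these compounds.

Working notes on the series. In a functional assay on HeLa cells (Homo sapiens) for antiproliferative activity, read by MTT assay, with a stated time of 48 h (on this read-out lower numbers stand for stronger inhibition and higher numbers for weaker inhibition), compound 1 (`COc1cc(-c2nnc3c(OC4COC4)cc(-c4ccc5[nH]ccc5c4)cn23)cc(OC)c1OC`) gives 2780 nM and compound 2 (`CCOc1cc(-c2ccc3ccn(C)c3c2)cn2c(-c3cc(OC)c(OC)c(OC)c3)nnc12`) gives 240 nM while compound 3 (`COc1cc(-c2nnc3c(OC4COC4)cc(-c4ccc5c(ccn5C)c4)cn23)cc(OC)c1OC`) gives 214 nM as the starting value for this step. Compound 3 therefore lies within the scatter of compound 2 and well under compound 1.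

Compound 4 (`CCCN1CC(Oc2cc(-c3ccc4c(ccn4C)c3)cn3c(-c4cc(OC)c(OC)c(OC)c4)nnc23)C1`) is the next to be read. Its whole difference from compound 3 is on the oxygen on the aromatic ring: 1-propylazetidin-3-yl in place of oxetan-3-yl on an oxygen on an aromatic ring and nothing else changes.

For the measured compounds named here, only one measured step exists, a 13-fold lower number from compound 1 to compound 3 (1.11 log units; beyond the scatter) with methyl in place of hydrogen on an aromatic nitrogen. That step is large, but it lies at another place, and compound 4 keeps the methyl. It therefore gives no size for the new change. Going by the values given here, no measured step covers a replacement of oxetan-3-yl, so the expectation rests on compound 3 at 214 nM and stays loose. A moderate move to a higher number in this assay is expected, though a result within the scatter would not surprise. Among the compounds with values here, the estimated move is a 2.1-fold higher number from compound 3 to compound 4 (0.32 log units; beyond the scatter) with no measured step to fix it. For compound 4 the expected value is 450 nM with a range of 100 nM to 2000 nM as estimated here.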

Compound 4, half-maximal inhibitory concentration: 211 nM
For compound 4 the middle estimate is 2.1-fold (0.33 log units) above the measured one; the range from low to high includes it.
By their numbers in this assay, from the lowest: compounds 4, 3 and 2 (each within the scatter of the next); then compound 1.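

In this assay, a 1.0-fold lower number from compound 3 to compound 4 (0.01 log units; within the scatter), so at this place, on an oxygen on an aromatic ring, 1-propylazetidin-3-yl and oxetan-3-yl cannot be told apart by this read-out. For the compounds shown here, this is the first information on this position, and it shows that the read-out stays within the scatter even though the group grows from 4 heavy atoms to 7 and its ring oxygen gives way to a ring nitrogen bearing a propyl chain. Going by these compounds alone, the only earlier step, a 13-fold lower number from compound 1 to compound 3 (1.11 log units; beyond the scatter), lies beyond the scatter, but at the aromatic nitrogen, so the two steps describe different places on the shared core, and nothing available explains why this exchange leaves the read-out in place.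

Open, on these data alone, is how far this place accepts other groups: the same azetidine ring carrying hydrogen, methyl or a longer chain such as hexyl on its nitrogen, or a propyl chain ending in a carboxylic acid, could read differently. Also open, as far as these compounds go, is whether 1-propylazetidin-3-yl reads the same with hydrogen in place of methyl on the aromatic nitrogen, as in compound 1.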